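Methyl in place of hydrogen on compound 2

The source may report more compounds than this note shows. Statements on the series, on what has been measured and on what is new or still open speak of the compounds shown alone.

In a physicochemical assay for acid dissociation, compound 1 `COc1ccnc(C[S+]([O-])c2nc3cc(OC(F)(F)C(F)F)ccc3[nH]2)c1OC` gives 8.08 and compound 2 `COc1ccnc(C[S+]([O-])c2nc3cc(OC(F)(F)C(F)F)ccc3[nH]2)c1` gives 7.91, so these two stand within the scatter of each other. Compound 3 `COc1cc(C[S+]([O-])c2nc3cc(OC(F)(F)C(F)F)ccc3[nH]2)ncc1C` has not been measured. It differs by methyl in place of hydrogen on an aromatic carbon, ortho to a methoxy group, taking 4-methoxypyridin-2-yl to 4-methoxy-5-methylpyridin-2-yl. For the measured compounds named here, only one measured step bears on this, and only indirectly, since it exchanges methoxy rather than methyl: a number 0.17 log units lower from compound 1 to compound 2 (within the scatter). On that single precedent, no shift beyond the scatter is expected in this assay. The estimated change is a number 0.06 log units higher from compound 2 to compound 3 (within the scatter). For compound 3 the expected value is 7.97, with an estimated range from 7.7 to 8.25.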

Compound 3, acid dissociation constant: 8
Compound 3: middle estimate off by 0.03 log units, on the low side; the range from low to high includes it.
By their numbers in this assay, from the lowest: compounds 2, 3 and 1 (each within the scatter of the next).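

In this assay, methyl in place of hydrogen on the aromatic carbon ortho to a methoxy group gives a number 0.09 log units higher from compound 2 to compound 3 (within the scatter). For the compounds shown here, this is the only direct reading at this place, two atoms from the ring nitrogen and para to a large group, whereas the earlier step concerned methoxy at a different place on the ring. At this place, then, the entry of 1 carbon leaves the read-out of compound 3 within the scatter of compound 2, and no measurement at hand accounts for this result.

Only hydrogen and methyl are shown at this place, so it stays open whether an amine, a carboxylic acid or a longer chain here would give a step beyond the scatter. A single step also cannot show whether methyl would read the same with the methoxy group replaced by hydrogen.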